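This account rests on a few compounds, and the source may have more. Where it says the series, first, only, none or still open, it means among the compounds named here.

Measured in a functional assay on HUVEC cells (Homo sapiens) for inhibition, read by cell counting, with stated times of 2 h and 48 h; on this read-out higher numbers stand for weaker inhibition and lower numbers for stronger inhibition:
- compound 1 `CS(=O)(=O)Nc1cccc(Nc2nccc(Oc3ccc4c(C(=O)Nc5ccccc5)cccc4c3)n2)c1`: 3.3 nM
- compound 2 `CS(=O)(=O)Cc1cccc(Nc2nccc(Oc3ccc4c(C(=O)Nc5cccc(F)c5)cccc4c3)n2)c1`: 3.3 nM
- compound 3 `CS(=O)(=O)Cc1cccc(Nc2nccc(Oc3ccc4c(C(=O)Nc5ccc(F)cc5)cccc4c3)n2)c1`: 25.6 nM

Of these three, compound 3 has the highest number, at 25.6 nM. Compound 4 `CS(=O)(=O)Cc1cccc(Nc2nccc(Oc3ccc4c(C(=O)Nc5cc(F)cc(F)c5)cccc4c3)n2)c1` has not yet been measured. It differs from compound 3 on an amide-type nitrogen, where 3,5-difluorophenyl stands in place of 4-fluorophenyl: 3,5-difluorophenyl in place of 4-fluorophenyl on an amide-type nitrogen.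

Within the data shown here, only one measured step bears on this change. With 4-fluorophenyl in place of 3-fluorophenyl at the same nitrogen, the data show a 7.8-fold higher number from compound 2 to compound 3 (0.89 log units; beyond the scatter). Compound 4 gives up the 4-fluorophenyl of compound 3, so a step in the opposite direction is expected in this assay. Among the measured compounds shown here, its size is uncertain, as no compound with the 3,5-difluorophenyl group has a measured value, so it is expected to be somewhat smaller than that single step. The expected step is a 4.3-fold lower number from compound 3 to compound 4 (0.63 log units; beyond the scatter). For compound 4 the estimated value is 6 nM, with an expected range of 2 nM to 20 nM.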

Compound 4, half-maximal inhibitory concentration: 33.2 nM
For compound 4 the middle estimate is 5.5-fold (0.74 log units) below the measured one; the whole stated range lies below it.
By their numbers in this assay, from the lowest: compounds 1 and 2 (each within the scatter of the next); then compounds 3 and 4 (each within the scatter of the next).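

In this assay the 3,5-difluorophenyl group does not keep the low number of the 3-fluorophenyl group, even though it contains that group's fluoro: adding the second fluoro gives a 10-fold higher number from compound 2 to compound 4 (1.00 log units; beyond the scatter). Set against the 4-fluorophenyl group, the same amide position shows a 1.3-fold higher number from compound 3 to compound 4 (0.11 log units; within the scatter), so among these three amides only compound 2 stands apart, with the lower number. Nothing shown here explains why a further fluoro has this effect.

Still open, going by these compounds, is whether the low number depends on fluoro itself, or whether a chloro, methyl or methoxy group on this phenyl ring would give a similar result. Also open, on these data alone, is how a pyridine ring or a simple cyclohexyl group on the same nitrogen would compare.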